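A few compounds are considered here, and "the series" means these few. Any claim that something is new, unique, unknown or untested is made for them only; others in the source may bear on it.

Of the compounds shown here, three have so far been tested in a functional assay on the whole organism (Abdomen, strain Swiss) for inhibition, with Mus musculus as the target, with stated times of 30 min, 10 min and 5 min, at a dose of 20 mg/kg by the oral route; on this read-out lower numbers stand for a weaker effect and higher numbers for a stronger effect at the one dose given. Compound 1 `Cc1c(C#N)c(-c2ccccc2)nn1CCCN1CCN(c2cccc(Cl)c2)CC1` gives 0% in this assay. Compound 2 `COc1cccc(N2CCN(CCCn3nc(-c4ccccc4)c(C#N)c3C)CC2)c1` shares the core of compound 1 and differs from it in one place, (methoxy in place of chloro on an aromatic carbon); in this assay compound 2 gives 21%. That single change made a step of a number 21 percentage points higher from compound 1 to compound 2 (beyond the scatter). Compound 3 `CC(=O)c1cccn1CCCN1CCN(c2cccc(Cl)c2)CC1` is built on another core; the difference between the two cores is not broken down here. In this assay compound 3 gives 41%, the highest of the three numbers, and its steps to compound 2 and to compound 1 are both beyond the usual scatter.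

Compound 4 `COc1cccc(N2CCN(CCCn3cccc3C(C)=O)CC2)c1` has not yet been measured. It stands to compound 3 exactly as compound 2 stands to compound 1: methoxy in place of chloro on an aromatic carbon. The surroundings of the change are described in the same words in both pairs, so this is the same change made on a second core, and it occurs twice among the compounds shown. Whether a change that raised the number on the core of compound 1 will also raise it on the core of compound 3 rests on one pair only, which leaves the expectation wide. Because a number 21 percentage points higher from compound 1 to compound 2 (beyond the scatter) was a modest rise, compound 4 is expected to move by a number 14 percentage points higher from compound 3 to compound 4 (beyond the scatter). In this assay compound 4 is therefore estimated at 55%, most likely between 30% and 80%.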

Compound 4, a percentage reported as inhibition, in the whole organism at one dose (the size of the read-out at that dose, not a potency): 26%
Beside the measured number, compound 4's estimate is 29 percentage points above it; measured number outside the range, below it.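

In this assay, the same exchange of chloro for methoxy that raised the number on the core of compound 1 gave a step of a number 15 percentage points lower from compound 3 to compound 4 (beyond the scatter) on the core of compound 3 and so did not repeat the rise. Placed side by side, the two steps run in opposite directions, and the gap between them is larger than the usual variation between repeated measurements can account for: the same change on two cores in this assay, a number 21 percentage points higher (beyond the scatter) from compound 1 to compound 2 and a number 15 percentage points lower (beyond the scatter) from compound 3 to compound 4, 36 percentage points apart, beyond the scatter of two such steps. This shows that, among these compounds, the outcome of the change depends on the core that carries it, so the result from one core cannot simply be carried over to the other; it does not show why the two cores differ, and with only two pairs at a single dose, it gives no rule for what the change would do on a third core.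

The compounds shown leave open how other groups, such as fluoro or an amine, would behave on an aromatic carbon of the same six-membered ring on each of the two cores. They also leave open whether a longer chain between the two halves of the molecule would alter the difference between the cores.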